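Replacing Butoxy with tert-Butyl on the Aryl Sulfonamide

This account rests on a few compounds, and the source may have more. Where it says the series, first, only, none or still open, it means among the compounds named here.

Compound 1, `CCCOc1ccc(S(=O)(=O)N2CCC(N3CCC(C)CC3)CC2)cc1`: 452 nM
Compound 2, `CC1CCN(C2CCN(S(=O)(=O)c3ccc(C(C)C)cc3)CC2)CC1`: 685 nM
Compound 3, `CCCCOc1ccc(S(=O)(=O)N2CCC(N3CCC(C)CC3)CC2)cc1`: 2300 nM

All three compounds were tested in a functional assay on DLD-1 cells (Homo sapiens) for antiproliferative activity, read by CellTiter-Glo, with a stated time of 72 h; on this read-out higher numbers stand for weaker inhibition and lower numbers for stronger inhibition. Compound 3 has the highest number of the three, separated from compound 2 by a 3.4-fold higher number from compound 2 to compound 3 (0.53 log units; beyond the scatter) and from compound 1 by a 5.1-fold higher number from compound 1 to compound 3 (0.71 log units; beyond the scatter). Compound 4, `CC1CCN(C2CCN(S(=O)(=O)c3ccc(C(C)(C)C)cc3)CC2)CC1`, differs from compound 3 in one place: tert-butyl in place of butoxy on an aromatic carbon. The step that bears most directly on this change is a 3.4-fold higher number from compound 2 to compound 3 (0.53 log units; beyond the scatter), which ran the other way, from isopropyl to butoxy; and a 1.5-fold higher number from compound 1 to compound 2 (0.18 log units; within the scatter) shows that isopropyl and propoxy gave similar numbers. Undoing the move to butoxy is therefore expected to bring the number in this assay back down by a modest step, a 2.7-fold lower number from compound 3 to compound 4 (0.43 log units; beyond the scatter). Compound 4 is estimated at 850 nM, with a range from 350 nM to 2300 nM.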

Compound 4, half-maximal inhibitory concentration: > 5000 nM
Compound 4 gave a limit, no number; the forecaster's own chance of this, stated with the estimate: 2%; middle value at least 5.8-fold (0.76 log units) away from the limit.
By their numbers in this assay, from the lowest: compounds 1 and 2 (each within the scatter of the next); then compound 3. At a limit, above all of these: compound 4.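

Compound 4 gave only a limit in this assay, not a number, so each step to it is a minimum: an at least 2.1-fold higher number from compound 3 to compound 4 (0.33 log units; beyond the scatter); an at least 7.2-fold higher number from compound 2 to compound 4 (0.86 log units; beyond the scatter); and an at least 11-fold higher number from compound 1 to compound 4 (1.04 log units; beyond the scatter). Tert-butyl on this aromatic carbon therefore does not match isopropyl, and shorter or unbranched groups are not interchangeable with it here. Adding a methyl in place of hydrogen to the group at this position raised the number on both cores: the same change on two cores in this assay, a 5.1-fold higher number (0.71 log units; beyond the scatter) from compound 1 to compound 3 and an at least 7.2-fold higher number (0.86 log units; beyond the scatter) from compound 2 to compound 4; the limit leaves it open whether they differ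

From the compounds shown here alone, how far compound 4 lies past its limit stays open. So does whether a methoxy or an amine on this aromatic carbon would bring the number down.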